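This account rests on a few compounds, and the source may have more. Where it says the series, first, only, none or still open, it means among the compounds named here.

Compound 1 `CCN1CCN(S(=O)(=O)CCCN2CCC(CNC(=O)c3cccc4c3OCCO4)CC2)CC1` gives 0.0501 nM in an assay on isolated protein for inhibition of 5-hydroxytryptamine receptor 4 (Homo sapiens) (on this read-out lower numbers stand for stronger inhibition and higher numbers for weaker inhibition), the lowest of the three numbers measured. Compound 2 `CS(=O)(=O)N1CCN(S(=O)(=O)CCCN2CCC(CNC(=O)c3cccc4c3OCCO4)CC2)CC1` gives 0.316 nM, and compound 3 `CC(C)S(=O)(=O)N1CCN(S(=O)(=O)CCCN2CCC(CNC(=O)c3cccc4c3OCCO4)CC2)CC1` gives 0.126 nM. Replacing the ethyl with a sulfonyl group weakens binding in both cases: the step is a 6.3-fold higher number from compound 1 to compound 2 (0.80 log units; beyond the scatter) and a 2.5-fold higher number from compound 1 to compound 3 (0.40 log units; beyond the scatter), while within the sulfonyl pair the step is a 2.5-fold lower number from compound 2 to compound 3 (0.40 log units; beyond the scatter). Compound 4 `CCCS(=O)(=O)N1CCN(S(=O)(=O)CCCN2CCC(CNC(=O)c3cccc4c3OCCO4)CC2)CC1` differs from compound 1 by propylsulfonyl in place of ethyl on an amine nitrogen in a ring. Because the two steps of a 6.3-fold higher number from compound 1 to compound 2 (0.80 log units; beyond the scatter) and a 2.5-fold higher number from compound 1 to compound 3 (0.40 log units; beyond the scatter) both raise the number modestly, a step of similar size is expected here. Compound 4 is therefore estimated at 0.16 nM in this assay, within 0.07 nM to 0.4 nM, a step of a 3.2-fold higher number from compound 1 to compound 4 (0.50 log units; beyond the scatter) that is expected rather than known.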

Compound 4, inhibition constant: 0.1 nM
The estimate for compound 4 lay 1.6-fold (0.20 log units) above the measured number; the range from low to high includes it.
By their numbers in this assay, from the lowest: compounds 1, 4 and 3 (each within the scatter of the next, the first and the last beyond it); then compound 2.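

In this assay, among the compounds shown here, propylsulfonyl is the only sulfonyl group on this ring nitrogen whose step from ethyl stays within the scatter, with a 2.0-fold higher number from compound 1 to compound 4 (0.30 log units; within the scatter). On the sulfonyl sulfur, propyl and isopropyl cannot be told apart, with a 1.3-fold lower number from compound 3 to compound 4 (0.10 log units; within the scatter), whereas extending methyl to propyl gives a 3.2-fold lower number from compound 2 to compound 4 (0.50 log units; beyond the scatter). No available evidence accounts for these steps. The compounds shown leave open whether a longer chain such as butyl or a phenyl ring on the sulfonyl sulfur would keep this level. They also leave open how an acetyl group on this nitrogen would compare.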